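Carbamoyl to hydroxymethyl on the anilino aryl ring

The source may hold more compounds than are shown below. What is called first, only, known or untested is meant among the compounds shown, and "the series" means these compounds.

Compound 1 `COc1cc(NC2=CC(=O)c3ncncc3C2=O)cc(OC)c1OC` gives 1600 nM in a functional assay on BXPC-3 cells (Homo sapiens) for cytotoxicity, read by MTT assay, with a stated time of 72 h; on this read-out higher numbers stand for weaker inhibition and lower numbers for stronger inhibition. Compound 2 `COC(=O)c1ccc(NC2=CC(=O)c3ncncc3C2=O)cc1` gives 5800 nM in this assay. Compound 3 `NC(=O)c1ccc(NC2=CC(=O)c3ncncc3C2=O)cc1` is reported in this assay only as > 10000 nM, which is a limit of the assay rather than a number (the limit of > 10000 nM in this assay, at which 1 of the 3 values shown sits). On the numbers shown, compound 3 therefore has no fixed position; it stands only at or beyond that limit, so its distance from compound 1 and compound 2 is open-ended.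

Among the compounds with values here, the one measured step that concerns this ring position is an at least 1.7-fold higher number from compound 2 to compound 3 (0.23 log units; that floor lies within the scatter), amino in place of methoxy on a carbonyl carbon. Its floor lies within the scatter, so it does not establish a direction by itself.

Compound 4 `O=C1C(Nc2ccc(CO)cc2)=CC(=O)c2ncncc21` differs from compound 3 as follows: hydroxymethyl in place of carbamoyl on an aromatic carbon. Within the data shown here, no measured step covers a carbamoyl to hydroxymethyl exchange, and the starting point is a limit, so the step can only be framed loosely. The expected step from compound 3 to compound 4 is an at least 1.2-fold lower number from compound 3 to compound 4 (0.09 log units; that floor lies within the scatter), without a direction that can be claimed beyond the scatter. For compound 4 the estimate in this assay is 8000 nM, with a range from 3000 nM to 25000 nM.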

Compound 4, half-maximal inhibitory concentration: 5700 nM
Estimate against measurement, compound 4: 1.4-fold (0.15 log units) above; low and high end bracket the measured number.
By their numbers in this assay, from the lowest: compound 1; then compounds 4 and 2 (each within the scatter of the next). At a limit, above all of these: compound 3.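

In this assay, within the data shown here, hydroxymethyl at this position, para to a large group, is the first group other than methoxycarbonyl to give a number on this aromatic ring without a carbonyl being needed, and a 1.0-fold lower number from compound 2 to compound 4 (0.01 log units; within the scatter) shows no separation between the two groups. The exchange of carbamoyl for hydroxymethyl reads as an at least 1.7-fold lower number from compound 3 to compound 4 (0.24 log units; that floor lies within the scatter), so even with the new value it has only a floor, and that floor sets no direction for the change. Compound 3 stands only at a limit, not at a number: the limit of > 10000 nM in this assay, at which 1 of the 4 values shown sits.

As far as these compounds go, the true size of the carbamoyl to hydroxymethyl step stays open, and so does whether any group at this position can move the number beyond the scatter from what compound 2 and compound 4 show. Among these compounds, a carboxylic acid, a primary amine or a longer chain ending in hydroxyl at the same place would test this, while compound 1 differs from compound 4 in more than one place and gives no step to set against these.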